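The source may report more compounds than this note shows. Statements on the series, on what has been measured and on what is new or still open speak of the compounds shown alone.

In an assay on HEK293 cells for antagonist activity at Nicotinic acetylcholine receptor alpha-4/beta-2 (Mus musculus), read by FLIPR, using a membrane potential dye (a lower number here means a stronger inhibitor, a higher number a weaker inhibitor), compound 2 `CCO[C@H]1CC=C2CCN(C)[C@H]2C1` gives only the limit of > 300000 nM. Compound 1 `CO[C@H]1CC[C@H]2CCN(C)[C@H]2C1`, with its saturated core, also gives only the limit of > 300000 nM. Compound 3 `CN1CCC2=CC[C@H](OCc3ccccc3)C[C@@H]21` likewise stays at the limit of > 300000 nM. The change from compound 2 to compound 4 `CN1CCC2=CC[C@H](O)C[C@@H]21` is hydrogen in place of ethyl on an oxygen on a saturated carbon. Going by the values given here, the one measured step at the same oxygen, a step that the two limits leave unreadable from compound 2 to compound 3, is left unreadable by its two limits; the shared thread across all three measured compounds is the limit of > 300000 nM in this assay, at which 3 of the 3 values shown sit. No measured change moves any compound off that limit, so the expected step is a number no higher from compound 2 to compound 4 (the limit leaves the size open), none beyond the scatter. Compound 4 is therefore estimated at 300000 nM, between 100000 nM and 1000000 nM, most likely again reported as a limit.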

Compound 4, half-maximal inhibitory concentration: > 100000 nM
Compound 4 gave a limit, no number; the forecaster's own chance of this, stated with the estimate: 85%; the middle value does not contradict the limit.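

Compound 2 and compound 4 both give only limits, not numbers, so the step between them cannot be read. The compounds shown leave open what change, if any, would bring a measurable value in this assay.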